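The source may hold more compounds than are shown below. What is called first, only, known or untested is meant among the compounds shown, and "the series" means these compounds.

In a functional assay on A549 cells (Homo sapiens) for inhibition, read by MTT assay, with a stated time of 48 h (a higher number here means a weaker inhibitor, a lower number a stronger inhibitor), three compounds built on one shared core have been measured:
compound 1, `CCCCCCCCNC(=O)/C=C/c1c(/C=C/c2ccc(OC)cc2)cc(OC)cc1OC`, gives 8660 nM;
compound 2, `C#CCNC(=O)/C=C/c1c(/C=C/c2ccc(OC)cc2)cc(OC)cc1OC`, gives 6930 nM;
compound 3, `COc1ccc(/C=C/c2cc(OC)cc(OC)c2/C=C/C(=O)Nc2cc(OC)c(OC)c(OC)c2)cc1`, gives 5140 nM.

Compound 2 stands second highest of the three numbers. Its nearest neighbour is compound 1, with a 1.2-fold lower number from compound 1 to compound 2 (0.10 log units; within the scatter), and its furthest is compound 3, with a 1.3-fold lower number from compound 2 to compound 3 (0.13 log units; within the scatter). Both of these steps, like a 1.7-fold lower number from compound 1 to compound 3 (0.23 log units; within the scatter), lie within the scatter, so the three compounds cannot be ordered against one another on these numbers.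

Compound 4, `COc1ccc(/C=C/c2cc(OC)cc(OC)c2/C=C/C(=O)N2CCC(c3ccccc3)CC2)cc1`, has not yet been measured in this assay. It differs from compound 2 in one place: 4-phenylpiperidin-1-yl in place of propargylamino on a carbonyl carbon. All three measured steps bear on this change, since each of them also exchanges the group on the amide-type nitrogen while leaving the rest of the core untouched, and none of them moved the number beyond the scatter. The change to compound 4 is larger in what is counted, yet the measured steps give no ground to expect a direction. Compound 4 is therefore expected to give 6000 nM, in a range from 2500 nM to 15000 nM, which means an expected step of a 1.2-fold lower number from compound 2 to compound 4 (0.06 log units; within the scatter).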

Compound 4, half-maximal inhibitory concentration: 6690 nM
Compound 4: middle estimate off by 1.1-fold (0.05 log units), on the low side; measured number inside the range.
By their numbers in this assay, from the lowest: compounds 3, 4, 2 and 1 (each within the scatter of the next).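

In this assay the exchange of propargylamino for 4-phenylpiperidin-1-yl on the carbonyl carbon gives a 1.0-fold lower number from compound 2 to compound 4 (0.02 log units; within the scatter) and the exchange of octylamino for the same group gives a 1.3-fold lower number from compound 1 to compound 4 (0.11 log units; within the scatter) so neither step leaves the scatter. The earlier compounds shown here all kept the amide hydrogen and varied only what hangs on that nitrogen, whereas compound 4 has no amide hydrogen and carries a six-membered non-aromatic ring and a six-membered aromatic ring, and even so its number stays within the scatter of those of compound 1 and compound 2. At this position, then, neither the loss of the amide hydrogen nor the much larger group entering with it, taken together, separates compound 4 from these two compounds, and no measurement is at hand that would explain this result.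

Going by these compounds, whether any group on this carbonyl carbon can move the number beyond the scatter stays open, for instance a piperazine ring, a chain ending in a primary amine, or a free carboxylic acid in place of the amide. Also open is what a hydroxyl in place of a methoxy group on the shared core would do, since all the compounds shown carry the same core.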